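A few compounds are considered here, and "the series" means these few. Any claim that something is new, unique, unknown or untested is made for them only; others in the source may bear on it.

Compound 1 `Cc1nnc(SCc2cc(=O)c3ccccc3o2)s1` — in a functional assay on HeLa cells (Homo sapiens) for cytotoxicity, read by MTT assay, with a stated time of 72 h (a higher number here means a weaker inhibitor, a lower number a stronger inhibitor), compound 1 gives > 25000 nM, which is a limit of the assay rather than a measured number.
Compound 2 `Cc1ccc2oc(CSc3nc4nc(C)cc(C)n4n3)cc(=O)c2c1` — in this assay compound 2 gives > 25000 nM, again a limit.
Compound 3 `Cc1cc(C)n2nc(SCc3cc(=O)c4cc(Cl)ccc4o3)nc2n1` — in this assay compound 3 gives > 25000 nM, again a limit.

Compound 1 therefore stands where every measured compound stands here: at the limit of > 25000 nM in this assay, at which 3 of the 3 values shown sit, so no number has yet been obtained for it and no ordering among the three is possible. Among the compounds with values here, the only single-point step among the measured compounds, a step that the two limits leave unreadable from compound 2 to compound 3, is likewise unreadable, since both of its ends are limits.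

Compound 4 `Cc1nnc(SCc2cc(=O)c3ccccc3o2)o1` is the next compound to be tested. It differs from compound 1 by 5-methyl-1,3,4-oxadiazol-2-yl in place of 5-methyl-1,3,4-thiadiazol-2-yl on a sulfur. Within the data shown here, none of the measured steps concerns this exchange, so there is nothing to suggest a step in either direction beyond the scatter; the step from compound 1 to compound 4 is expected to be a step that the limit leaves unreadable from compound 1 to compound 4. Compound 4 is therefore expected to sit at 30000 nM, most probably reported again only as a limit, with a range from 10000 nM to 100000 nM.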

Compound 4, half-maximal inhibitory concentration: > 25000 nM
Compound 4: a limit, no number; the forecaster's own chance of this, stated with the estimate: 80%; the middle value is on the limit's open side.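

Compound 1 and compound 4 both give only a limit, so no step can be read between them: the limit of > 25000 nM in this assay, at which 4 of the 4 values shown sit. The compounds shown leave open what number any of them would give in this assay, and whether swapping 5-methyl-1,3,4-thiadiazol-2-yl for 5-methyl-1,3,4-oxadiazol-2-yl changes that number.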